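Cytotoxicity notes on the shared core, compounds 1 to 4

The source may hold more compounds than are shown below. What is called first, only, known or untested is meant among the compounds shown, and "the series" means these compounds.

Compound 1, `Cc1ccsc1C(c1c(C)noc1C)N1CCN(c2ncnc3c2cnn3-c2ccccc2)CC1`, reaches only the limit > 25000 nM in a functional assay on cells (Rhabdomyosarcoma cell, Homo sapiens) for cytotoxicity; a higher number here means a weaker inhibitor, a lower number a stronger inhibitor.
Compound 2, `c1ccc(C(c2ccco2)N2CCN(c3ncnc4c3cnn4-c3ccccc3)CC2)cc1`, reaches only the limit > 25000 nM in this assay.
Compound 3, `FC(F)(F)c1ccc(C(c2ccccc2)N2CCN(c3ncnc4c3cnn4-c3ccccc3)CC2)cc1`, reaches only the limit > 25000 nM in this assay.

Compound 3 thus stands where every measured member of the series stands: at the limit of > 25000 nM in this assay, at which 3 of the 3 values shown sit, with no number for any of them. Among the measured compounds shown here, the one step that can be drawn between measured compounds, a step that the two limits leave unreadable from compound 2 to compound 3, is not readable for the same reason, so its size is unknown.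

Compound 4, `c1ccc(C(c2cccnc2)N2CCN(c3ncnc4c3cnn4-c3ccccc3)CC2)cc1`, is not yet measured. It differs from compound 3 by pyridin-3-yl in place of 4-(trifluoromethyl)phenyl on a saturated chain carbon bound to an amine nitrogen in a ring and an aromatic carbon. For the measured compounds named here, no measured step bears readably on this change; the only step available ends at the limit on both sides and gives no size. The three limits together say nothing about whether an exchange on this saturated chain carbon moves this assay at all.

The expectation for compound 4 therefore rests on the three limits alone. Compound 4 is estimated at 30000 nM, with a range from 8000 nM to 120000 nM, and most likely it too reports only a limit. The expected step from compound 3 is a step that the limit leaves unreadable from compound 3 to compound 4, that is, none that could be read beyond the scatter.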

Compound 4, half-maximal inhibitory concentration: > 25000 nM
Compound 4: no number, only a limit (the forecaster's own chance of this, stated with the estimate: 85%); the middle value is on the limit's open side.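

In this assay compound 4 gives > 25000 nM, a limit and not a number. Among the compounds shown here, no step from compound 2 or compound 3 to compound 4 can be read, and the series stands at a single place: the limit of > 25000 nM in this assay, at which 4 of the 4 values shown sit. The compounds shown leave open whether any exchange on the saturated chain carbon moves this assay at all.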